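Replacing 4-nitrophenyl with 3-methoxyphenyl in compound 1

The source may report more compounds than this note shows. Statements on the series, on what has been measured and on what is new or still open speak of the compounds shown alone.

In a functional assay on HCT-116 cells (Homo sapiens) for antiproliferative activity, read by MTT assay, with a stated time of 48 h (a higher number here means a weaker inhibitor, a lower number a stronger inhibitor), compound 1 `O=C(Nc1cc(Sc2ncn[nH]2)c(O)c2ccccc12)c1ccc([N+](=O)[O-])cc1` gives > 100000 nM, which is a limit and not a number. Compound 2 `O=C(/C=C/c1ccccc1)Nc1cc(Sc2ncn[nH]2)c(O)c2ccccc12` gives > 100000 nM, also a limit. Only compound 3 `O=C(Nc1cc(Sc2ncn[nH]2)c(O)c2ccccc12)c1ccc(Cl)cc1` gives a true number, 43300 nM.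

Compound 4 `COc1cccc(C(=O)Nc2cc(Sc3ncn[nH]3)c(O)c3ccccc23)c1` keeps the core of compound 1 but has 3-methoxyphenyl in place of 4-nitrophenyl on a carbonyl carbon. Changes at this carbonyl carbon gave a step that the two limits leave unreadable from compound 1 to compound 2, an at least 2.3-fold lower number from compound 1 to compound 3 (0.36 log units; beyond the scatter) and an at least 2.3-fold lower number from compound 2 to compound 3 (0.36 log units; beyond the scatter). The two readable steps give only a minimum size, and both lead to compound 3. A modest fall in the number is therefore expected, with little certainty. The estimated change is an at least 1.8-fold lower number from compound 1 to compound 4 (0.25 log units; that floor lies within the scatter). For compound 4 the expected value is 55000 nM, within an estimated range of 20000 nM to 120000 nM.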

Compound 4, half-maximal inhibitory concentration: > 100000 nM
Compound 4 ended at the assay's limit; the forecaster's own chance of this, stated with the estimate: 35%; middle value at least 1.8-fold (0.25 log units) from the limit.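

In this assay 3-methoxyphenyl in place of 4-chlorophenyl gives an at least 2.3-fold higher number from compound 3 to compound 4 (0.36 log units; beyond the scatter) and so shows that a substituted phenyl on this carbonyl carbon does not by itself bring a measurable value. Going by these compounds alone, compound 3 remains the only compound here with a true number, while compound 1 and compound 4 carry other substituted phenyl groups. The steps from compound 1 and compound 2 to compound 4 cannot be read, because all three compounds sit at one limit: the limit of > 100000 nM in this assay, at which 3 of the 4 values shown sit.

From the compounds shown here alone, how far beyond that limit these three compounds lie remains open. So does whether a phenyl ring carrying an amine or a carboxylic acid, or a longer chain, would give a true number.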